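The compounds below may be only part of what the source reports. "The series", "measured", "known", "first", "only" and "open" are said of these compounds alone.

Compound 1 `O=C(CSc1nc2ccc(NC(=O)c3ccc(Cl)cc3)cc2s1)NCc1ccc(Cl)cc1`: 17800 nM
Compound 2 `COc1ccc(CNC(=O)CSc2nc3ccc(NC(=O)CCl)cc3s2)cc1`: 2000 nM
Compound 3 `CC(=O)Nc1ccc2nc(SCC(=O)NCc3ccc(Cl)cc3)sc2c1`: 6700 nM

In a functional assay on HepG2 cells (Homo sapiens) for cytotoxicity, read by MTT assay, with a stated time of 48 h (on this read-out lower numbers stand for stronger inhibition and higher numbers for weaker inhibition), compound 3 stands second highest of these three numbers. Compound 1 lies nearest, reached by a 2.7-fold lower number from compound 1 to compound 3 (0.42 log units; beyond the scatter), while compound 2 lies furthest, with a lower number than compound 3 by a gap beyond the scatter.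

Compound 4 `O=C(CSc1nc2ccc(NC(=O)CCl)cc2s1)NCc1ccc(Cl)cc1` differs from compound 3 by chloro in place of hydrogen on a saturated chain carbon bound to a carbonyl carbon. Within the data shown here, no measured step covers this exact change; the one measured step, a 2.7-fold lower number from compound 1 to compound 3 (0.42 log units; beyond the scatter), alters a different part of the molecule. Compound 2, which also carries the chloromethyl carbonyl group, gives 2000 nM, the lowest of the three numbers. On that basis compound 4 is expected to move by a 2.7-fold lower number from compound 3 to compound 4 (0.43 log units; beyond the scatter) toward a lower number. The estimate for compound 4 is 2500 nM, ranging from 800 nM to 8000 nM.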

Compound 4, half-maximal inhibitory concentration: 1800 nM
For compound 4 the middle estimate is 1.4-fold (0.14 log units) above the measured one, within the range that was stated.
By their numbers in this assay, from the lowest: compounds 4 and 2 (each within the scatter of the next); then compound 3; then compound 1.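

In this assay, swapping one hydrogen for chloro on the saturated chain carbon bound to the carbonyl carbon gives a 3.7-fold lower number from compound 3 to compound 4 (0.57 log units; beyond the scatter), so this small change, acetamido to ((chloromethyl)carbonyl)amino, is enough to shift the number beyond the scatter. Chloromethyl in place of 4-chlorophenyl on the carbonyl carbon gives a 9.9-fold lower number from compound 1 to compound 4 (1.00 log units; beyond the scatter), whereas chloro in place of methoxy on an aromatic carbon gives a 1.1-fold lower number from compound 2 to compound 4 (0.05 log units; within the scatter), which is within the scatter. Nothing measured here explains why the chloro shifts the number. Going by these compounds, whether bromo, an amine or a longer chain in place of this chloro would give a similar number remains open.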